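The compounds below may be only part of what the source reports. "The series", "measured", "known", "first", "only" and "open" are said of these compounds alone.

Measured so far:
compound 1 `CCC(O)[C@@H](CC)Nc1nc(NCc2ccccn2)c2ncn(C(C)C)c2n1`: 29000 nM
compound 2 `CC[C@@H](Nc1nc(NCc2ccccn2)c2ncn(C(C)C)c2n1)C(O)C(C)(C)C`: 29000 nM

Among the compounds with values here, in a functional assay on HCT-116 cells (Homo sapiens) for inhibition, read by sulforhodamine B assay, with a stated time of 96 h (on this read-out higher numbers stand for weaker inhibition of growth and lower numbers for stronger inhibition of growth), compound 2 stands level with the only other measured analogue, at 29000 nM. Compound 3 `CC[C@H](Nc1nc(NCc2ccccn2)c2ncn(C(C)C)c2n1)C(C)O` differs from it as follows: 1-(1-hydroxyethyl)propyl in place of 1-ethyl-2-hydroxy-3,3-dimethylbutyl on a nitrogen on an aromatic ring. Within the data shown here, one measured step bears on this: no change at the digits printed from compound 1 to compound 2 (within the scatter), where tert-butyl replaced ethyl in the same side chain. No step beyond the scatter is therefore expected in this assay, although this is a single step and it does not test the defined stereocentre. The expected step is a 1.2-fold lower number from compound 2 to compound 3 (0.06 log units; within the scatter). Compound 3 is estimated at 25000 nM, with an expected range of 10000 nM to 60000 nM.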

Compound 3, concentration for 50% growth inhibition: 10000 nM
The estimate for compound 3 lay 2.5-fold (0.40 log units) above the measured number; measured number inside the range.
By their numbers in this assay, from the lowest: compound 3; then compounds 1 and 2 (each within the scatter of the next).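

In this assay, the side chain on a nitrogen on an aromatic ring does affect growth inhibition: 1-(1-hydroxyethyl)propyl gives a 2.9-fold lower number from compound 2 to compound 3 (0.46 log units; beyond the scatter) and a 2.9-fold lower number from compound 1 to compound 3 (0.46 log units; beyond the scatter). Within the data shown here, the earlier pair showed no such separation, with 1-ethyl-2-hydroxybutyl and 1-ethyl-2-hydroxy-3,3-dimethylbutyl level, so this side chain is the first to stand apart, though only modestly. No available evidence accounts for this difference. Open, going by these compounds, are the separate contribution of the defined stereocentre and the outcome of replacing the hydroxyl with an amine or a carboxylic acid.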